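A Methyl Group Added Where Only Limits Are Known

A few compounds are considered here, and "the series" means these few. Any claim that something is new, unique, unknown or untested is made for them only; others in the source may bear on it.

Three related compounds have been tested in a functional assay on NCI-H460 cells (Homo sapiens) for cytotoxicity, read by MTT assay, with a stated time of 24 h; on this read-out higher numbers stand for weaker inhibition and lower numbers for stronger inhibition. Compound 1 `C=CCn1c(=O)c(C=O)cc2ccccc21` gives > 100000 nM, which is a limit of the assay and not a number. Compound 2 `C#CCn1c(=O)c(C=O)cc2ccccc21` gives > 100000 nM, which is also a limit. Compound 3 `C#CCn1c(=O)c(C=O)cc2cc(F)ccc21` gives > 100000 nM, again a limit. Compound 2 therefore has no exact value, and the whole set shares (the limit of > 100000 nM in this assay, at which 3 of the 3 values shown sit).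

Compound 4 `C#CCn1c(=O)c(C=O)cc2cc(C)ccc21` has not yet been measured. It differs from compound 2 by a single change, methyl in place of hydrogen on an aromatic carbon.

Among the compounds with values here, two measured steps bear on this change. The closer one also replaces hydrogen on an aromatic carbon: a step that the two limits leave unreadable from compound 2 to compound 3. The other changes the chain on the aromatic nitrogen: a step that the two limits leave unreadable from compound 1 to compound 2. Neither has a size that can be read, so neither gives a measured effect to carry over. In this assay, no step beyond the usual scatter is expected, and no direction can be named. The expected change is a step that the limit leaves unreadable from compound 2 to compound 4. For compound 4 the estimated value is 120000 nM, with an expected range from 50000 nM to 300000 nM.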

Compound 4, half-maximal inhibitory concentration: > 100000 nM
Compound 4 ended at the assay's limit (the forecaster's own chance of this, stated with the estimate: 90%); the middle value lies beyond the limit too.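

Compound 4 gives > 100000 nM, which is a limit of the assay and not a number, and neither the step from compound 2 nor the step from compound 3 to it can be read. All the compounds now share one result: the limit of > 100000 nM in this assay, at which 4 of the 4 values shown sit.

From the compounds shown here alone, whether any change to the shared core would give a measurable value in this assay remains open.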